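Oxetan-3-yl Replacing Methylsulfonyl on Compound 3

The compounds below may be only part of what the source reports. "The series", "measured", "known", "first", "only" and "open" are said of these compounds alone.

In a functional assay on MV4-11 cells (Homo sapiens) for inhibition, read by luminescence, with a stated time of 72 h (on this read-out higher numbers stand for weaker inhibition and lower numbers for stronger inhibition), compound 1 `CC(=O)c1c(C)c2ccc(Nc3nccc(-c4cccnc4)n3)cc2oc1=O` gives 12900 nM, compound 2 `CCN1C(=O)COc2c(CN3CCN(C(C)=O)CC3)cc(Nc3ncc(F)c(-c4ccc(F)cc4OC)n3)cc21` gives 17 nM and compound 3 `CCN1C(=O)COc2c(CN3CCN(S(C)(=O)=O)CC3)cc(Nc3ncc(F)c(-c4ccc(F)cc4OC)n3)cc21` gives 15 nM. Compound 3 therefore sits level with compound 2, within the scatter, and far from compound 1. Compound 4 `CCN1C(=O)COc2c(CN3CCN(C4COC4)CC3)cc(Nc3ncc(F)c(-c4ccc(F)cc4OC)n3)cc21` carries oxetan-3-yl in place of methylsulfonyl on an amine nitrogen in a ring. Among the measured compounds shown here, the only measured step at that nitrogen is a 1.1-fold lower number from compound 2 to compound 3 (0.05 log units; within the scatter), with methylsulfonyl in place of acetyl, and it lies within the scatter. For the measured compounds named here, no oxetan-3-yl analogue has yet been measured, so this evidence is limited. The expected step is a 1.3-fold higher number from compound 3 to compound 4 (0.12 log units; within the scatter), with no change beyond the scatter anticipated. For compound 4 the estimated value is 20 nM, with an expected range of 8 nM to 50 nM.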

Compound 4, half-maximal inhibitory concentration: 105 nM
Estimate against measurement, compound 4: 5.3-fold (0.72 log units) below; measured number outside the range, above it.
By their numbers in this assay, from the lowest: compounds 3 and 2 (each within the scatter of the next); then compound 4; then compound 1.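

In this assay the group on this amine nitrogen proves to matter: there is a 7.0-fold higher number from compound 3 to compound 4 (0.85 log units; beyond the scatter) and a 6.2-fold higher number from compound 2 to compound 4 (0.79 log units; beyond the scatter) here, whereas acetyl and methylsulfonyl stood level within the scatter. The position therefore does not treat all groups of equal heavy-atom count alike, since oxetan-3-yl and methylsulfonyl both have 4 heavy atoms. No evidence is available to explain this difference.

From the compounds shown here alone, whether a simple alkyl group such as methyl or a free amine hydrogen on this nitrogen would track with oxetan-3-yl or with acetyl and methylsulfonyl remains open. So does whether a larger saturated ring, such as tetrahydropyran-4-yl, would behave like oxetan-3-yl.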